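Swapping the Naphthoyl Cap for a Dimethylaminobenzoyl Group

A few compounds are considered here, and "the series" means these few. Any claim that something is new, unique, unknown or untested is made for them only; others in the source may bear on it.

Measured compounds:
compound 1 `Cc1cc(C)cc(CNC(=O)CN(CCCCCC(=O)Nc2ccccc2N)C(=O)c2cc(C)cc(C)c2)c1` — 5100 nM
compound 2 `Nc1ccccc1NC(=O)CCCCCN(CC(=O)NCc1ccccc1)C(=O)c1cccc2ccccc12` — 22800 nM
compound 3 `Nc1ccccc1NC(=O)CCCCCN(CC(=O)NC1CCCCC1)C(=O)c1cccc2ccccc12` — 18100 nM

In a functional assay on A2780 cells (Homo sapiens) for cytotoxicity, read by MTT assay, with a stated time of 72 h (on this read-out lower numbers stand for stronger inhibition and higher numbers for weaker inhibition), compound 2 gives 22800 nM, the highest of the three numbers. Compound 3 stands nearest, with a 1.3-fold lower number from compound 2 to compound 3 (0.10 log units; within the scatter) through cyclohexyl in place of benzyl on an amide-type nitrogen. Compound 1, which differs from compound 2 in two places, stands furthest away, beyond the scatter. The unmeasured compound 4 `CN(C)c1ccc(C(=O)N(CCCCCC(=O)Nc2ccccc2N)CC(=O)NCc2ccccc2)cc1` arises from compound 2 by 4-(dimethylamino)phenyl in place of naphthalen-1-yl on a carbonyl carbon. Among the measured compounds shown here, no measured step touches the acyl group, so nothing bears directly on this change; the only clue is the lower number of compound 1, which carries a smaller aryl on that carbonyl but also a different amide substituent. Compound 4 is therefore expected to give 14000 nM (range 5000 nM to 40000 nM), with a 1.6-fold lower number from compound 2 to compound 4 (0.21 log units; within the scatter) estimated to lie near the edge of the scatter.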

Compound 4, half-maximal inhibitory concentration: 18500 nM
Compound 4: the middle estimate sits 1.3-fold (0.12 log units) below what was measured; the range from low to high includes it.
By their numbers in this assay, from the lowest: compound 1; then compounds 3, 4 and 2 (each within the scatter of the next).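

In this assay, 4-(dimethylamino)phenyl in place of naphthalen-1-yl on a carbonyl carbon gives a 1.2-fold lower number from compound 2 to compound 4 (0.09 log units; within the scatter). Among the compounds shown here, this is the first measured step at this position, and it shows that, with benzyl on the amide-type nitrogen, exchanging the two aromatic rings for one ring bearing a dimethylamino group does not move the number beyond the scatter. No available evidence offers an explanation for this outcome.

Still open, from the compounds shown here alone, is how a pyridine ring or a 4-methoxyphenyl group would read on this carbonyl carbon. Also open, going by these compounds, is whether the step would hold with cyclohexyl on the amide-type nitrogen.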